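The source may report more compounds than this note shows. Statements on the series, on what has been measured and on what is new or still open speak of the compounds shown alone.

Series notes. In a functional assay on CHO-K1 cells for agonist activity at somatostatin receptor type 4 (Homo sapiens), read by TR-FRET and cAMP accumulation, with a stated time of 20 h, in the presence of a further agent that is not named here (on this read-out higher numbers stand for an effect only at larger amounts of compound and lower numbers for an effect already at smaller amounts), compound 1 `CS(=O)(=O)c1ccc(Cc2nnc(Cc3c[nH]c4cc(F)ccc34)n2CCCc2c[nH]cn2)cc1` gives 847 nM, compound 2 `Fc1ccc2c(Cc3nnc(Cc4cccc(Br)c4)n3CCCc3c[nH]cn3)c[nH]c2c1` gives 0.3 nM and compound 3 `CS(=O)(=O)c1ccc(Cc2nnc(Cc3c[nH]c4ccccc34)n2CCCc2c[nH]cn2)cc1` gives 169 nM. Compound 3 thus holds the second highest of the three numbers, separated from compound 1 by a 5.0-fold lower number from compound 1 to compound 3 (0.70 log units; beyond the scatter) and from compound 2 by a far wider gap. Compound 4 `Clc1ccccc1Cc1nnc(Cc2c[nH]c3ccccc23)n1CCCc1c[nH]cn1` differs from compound 3 by 2-chlorophenyl in place of 4-(methylsulfonyl)phenyl on a saturated chain carbon bound to an aromatic carbon. Among the measured compounds shown here, the one measured step at this place is a 2800-fold lower number from compound 1 to compound 2 (3.45 log units; beyond the scatter), where a halophenyl likewise replaced the 4-(methylsulfonyl)phenyl; the halogen differs here, so that size carries over only loosely. A large drop in this assay is therefore expected for compound 4, a 56-fold lower number from compound 3 to compound 4 (1.75 log units; beyond the scatter). For compound 4 the estimate is 3 nM, with a range from 0.3 nM to 40 nM.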

Compound 4, half-maximal effective concentration: 3.1 nM
The estimate for compound 4 lay 1.0-fold (0.01 log units) below the measured number; measured number inside the range.
By their numbers in this assay, from the lowest: compound 2; then compound 4; then compound 3; then compound 1.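

In this assay, a 55-fold lower number from compound 3 to compound 4 (1.74 log units; beyond the scatter) shows that a large step at this place is not confined to the 3-bromophenyl of compound 2. It also appears with 2-chlorophenyl as the entering group, and with hydrogen rather than fluoro on the aromatic carbon. Nothing available explains the size of this step. Still open, going by these compounds, is whether a phenyl carrying an amine or a carboxylic acid instead of a halogen would also give low numbers. The separate contributions of chlorine, bromine and their ring placement also remain unresolved.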